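The source may report more compounds than this note shows. Statements on the series, on what has been measured and on what is new or still open speak of the compounds shown alone.

Measured so far in an assay for inhibition of betaine--homocysteine S-methyltransferase 1 (Homo sapiens), tested at 20 uM; a lower number here means less inhibition, a higher number more inhibition at the concentration tested (going by the name of the read-out):
compound 1, `NC(CCSCCNCC(=O)O)C(=O)O`, gives 37.1%;
compound 2, `C[C@H](NCCSCCC(N)C(=O)O)C(=O)O`, gives 19.8%;
compound 3, `NC(CCCCCCCC(=O)O)C(=O)O`, gives 2.11%.

Compound 2 stands second highest of the three numbers. Compound 1 lies above it, the gap being the step of a number 17.3 percentage points lower from compound 1 to compound 2 (beyond the scatter), and compound 3 lies further below it; both gaps are beyond the scatter.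

Compound 4, `NC(CCSCCNCCC(=O)O)C(=O)O`, is not yet measured. It differs from compound 2 in one place: 2-carboxyethyl in place of 1-carboxyethyl on an amine nitrogen. Going by the values given here, the only measured step that bears on this change is a number 17.3 percentage points lower from compound 1 to compound 2 (beyond the scatter), where a methyl placed on the saturated chain carbon bound to the amine nitrogen and the carbonyl carbon lowered inhibition. Among the compounds with values here, compound 4 carries no methyl on that carbon, which points toward some recovery; the longer 2-carboxyethyl chain has no measured counterpart, so its effect is unknown and the expectation is held wide. The step of a number 8.2 percentage points higher from compound 2 to compound 4 (within the scatter) is expected to be upward and modest. Compound 4 is estimated at 28%, with a range from 12% to 45%.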

Compound 4, a percentage reported as inhibition, at one concentration (the size of the read-out at that concentration, not a potency): 0%
For compound 4 the middle estimate is 28 percentage points above the measured one; measured number below the stated range.
By their numbers in this assay, from the lowest: compounds 4 and 3 (each within the scatter of the next); then compound 2; then compound 1.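

In this assay, the atoms of the acid side chain stay the same, yet 2-carboxyethyl in place of 1-carboxyethyl on the amine nitrogen gives a number 19.8 percentage points lower from compound 2 to compound 4 (beyond the scatter), so at this position the way those atoms are joined matters, not only their number and kind. Measured from the unbranched parent, carboxymethyl in place of carboxy on the saturated chain carbon bound to the amine nitrogen gives a number 37.1 percentage points lower from compound 1 to compound 4 (beyond the scatter), which shows that this chain carbon accepts neither the added methyl of compound 2 nor the added carbon of compound 4 without a drop in the read-out. Nothing available explains these losses.

Still open, on these data alone, is whether a 3-carboxypropyl group on the amine nitrogen behaves like 2-carboxyethyl. Also open, as far as these compounds go, is whether a primary amide or a tetrazole can stand in for the carboxylic acid of the carboxymethyl group.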